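Adding a Hydroxycyclopentylamino Group to Compound 2

The compounds below may be only part of what the source reports. "The series", "measured", "known", "first", "only" and "open" are said of these compounds alone.

Compound 2 `COc1cc[nH]c1/C=C1\C(=O)Nc2ccc([N+](=O)[O-])cc21` carries a hydrogen at the position examined here, and in a functional assay on RKO cells (Homo sapiens) for antiproliferative activity, read by MTT assay, with a stated time of 5 days (on this read-out lower numbers stand for stronger inhibition and higher numbers for weaker inhibition), compound 2 gives 692 nM. Among the measured compounds shown here, this is the only plain number available; the other result is a limit. Compound 1 `COc1cc[nH]c1/C=C1\C(=O)Nc2ccc([N+](=O)[O-])c(N3CCC(O)CC3)c21` in this assay gives < 10 nM, which is a limit of the assay and not a number. The measured step of an at least 69-fold higher number from compound 1 to compound 2 (1.84 log units; beyond the scatter) shows that removing 4-hydroxypiperidin-1-yl weakened inhibition markedly. Compound 3 `COc1cc[nH]c1/C=C1\C(=O)Nc2ccc([N+](=O)[O-])c(N[C@H]3CC[C@H](O)C3)c21` differs from compound 2 by (3-hydroxycyclopentyl)amino in place of hydrogen on an aromatic carbon. This puts a hydroxyl-bearing ring back at the same aromatic carbon, so a shift toward stronger inhibition of similar size is expected for compound 3 in this assay because an at least 69-fold higher number from compound 1 to compound 2 (1.84 log units; beyond the scatter) was seen when such a group was removed. The estimate for compound 3 is therefore 15 nM, between 3 nM and 80 nM, an expected step of a 46-fold lower number from compound 2 to compound 3 (1.66 log units; beyond the scatter).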

Compound 3, half-maximal inhibitory concentration: 339 nM
For compound 3 the middle estimate is 23-fold (1.35 log units) below the measured one; measured number above the stated range.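

In this assay, a hydroxyl-bearing ring at this aromatic carbon does not by itself restore the large gain: the change from hydrogen to (3-hydroxycyclopentyl)amino gives a 2.0-fold lower number from compound 2 to compound 3 (0.31 log units; beyond the scatter). Replacing 4-hydroxypiperidin-1-yl with (3-hydroxycyclopentyl)amino at the same carbon gives an at least 33-fold higher number from compound 1 to compound 3 (1.53 log units; beyond the scatter), so the identity of the group matters far more here than the mere presence of a ring with a hydroxyl. Compound 1 stands at a limit of the assay and not at a number, so this step marks a minimum size: the limit of < 10 nM in this assay, at which 1 of the 3 values shown sits.

The compounds shown leave open whether ring size, the way the ring is attached, or the place of the hydroxyl accounts for the gap. Also open, as far as these compounds go, is how a piperidin-1-yl group without the hydroxyl, or a morpholin-4-yl group, would behave at this carbon.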